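Notes on replacing 3,4-difluorophenyl in compound 2

The compounds below may be only part of what the source reports. "The series", "measured", "known", "first", "only" and "open" are said of these compounds alone.

Measured in an ADME assay on microsomes from liver (Homo sapiens) for metabolic stability, read by LC-MS, with a stated time of 30 min, tested at 1 uM; a higher number here means faster removal of the compound, a lower number slower removal:
- compound 1 `C[C@@H](c1c[nH]c2ncccc12)c1nnc2ccc(-c3cnn(C)c3)nn12`: < 7.6 mL.min-1.g-1 (a limit)
- compound 2 `Fc1ccc(-c2ccc3nnc(Cc4ccc5ncccc5c4)n3n2)cc1F`: 13.4 mL.min-1.g-1
- compound 3 `Nc1cnc2nnn(Cc3ccc4ncccc4c3)c2n1`: < 7.6 mL.min-1.g-1 (a limit)

For the measured compounds named here, compound 2 holds the only actual number in the set, 13.4 mL.min-1.g-1. The other two results are limits and not numbers, as the limit of < 7.6 mL.min-1.g-1 in this assay, at which 2 of the 3 values shown sit, shows. How far compound 2 lies from compound 1 and compound 3 cannot be read from limits.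

The next compound to be measured is compound 4 `CN(C)c1ccc2nnc(Cc3ccc4ncccc4c3)n2n1`. It carries dimethylamino in place of 3,4-difluorophenyl on an aromatic carbon. Going by the values given here, no measured pair in the set isolates a single change, so there is no direct precedent for the size of this step in this assay.

Among the compounds with values here, the only guide is indirect, and it rests on three compounds. Compound 1 lacks 3,4-difluorophenyl and reports the limit < 7.6 mL.min-1.g-1. Compound 3 also lacks that group and reports the limit < 7.6 mL.min-1.g-1. On that basis, a lower value is the expected direction for compound 4.

A small fall that stays within the usual scatter is expected: a 1.3-fold lower number from compound 2 to compound 4 (0.13 log units; within the scatter). The estimate for compound 4 is 10 mL.min-1.g-1, with an expected range of 6 mL.min-1.g-1 to 22 mL.min-1.g-1.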

Compound 4, intrinsic clearance in microsomes in the Homo sapiens assay: 35 mL.min-1.g-1
The estimate for compound 4 lay 3.5-fold (0.54 log units) below the measured number, and the stated range ends below it.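

Dimethylamino in place of 3,4-difluorophenyl, on the aromatic carbon next to the ring nitrogen, gives the first single-place step in the Homo sapiens assay, and it runs upward: a 2.6-fold higher number from compound 2 to compound 4 (0.42 log units; beyond the scatter). So in this pair, taking out the six-membered aromatic ring of carbon does not bring the number down, and compound 4 stands as a measured number in the Homo sapiens assay rather than joining the two compounds that report a limit: the limit of < 7.6 mL.min-1.g-1 in the Homo sapiens assay, at which 2 of the 4 values shown sit. For the compounds shown here, the same change also raises the number in a physicochemical assay for solubility, measured as kinetic solubility, at pH 6.5; a lower number here means a less soluble compound, a higher number a more soluble compound (compound 2 gives 11500 nM and compound 4 gives 134000 nM), so the one readable pair at this position pairs higher solubility with faster removal: the measured solubility of compound 2, 11500 nM, and of compound 4, 134000 nM, a 12-fold higher number (1.07 log units; beyond the scatter).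

With a single pair, the step in the Homo sapiens assay cannot be divided between the loss of 3,4-difluorophenyl and the entry of dimethylamino. Going by these compounds, whether a primary amine, an ether or a nitrile on the same carbon would hold the higher number in the physicochemical assay without the higher number in the Homo sapiens assay remains open.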